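From nitro to dimethylamino on the shared core

The source may hold more compounds than are shown below. What is called first, only, known or untested is meant among the compounds shown, and "the series" means these compounds.

Compound 1 `COc1ccc(/C=C/C(=O)/C(C)=C/c2ccccc2)cc1` gives 51000 nM
Compound 2 `C/C(=C\c1ccccc1)C(=O)/C=C/c1ccc([N+](=O)[O-])cc1` gives 26000 nM

In an ADME assay on J774.A1 cells (Mus musculus) for cytotoxicity, read by MTT assay, with a stated time of 48 h (on this read-out lower numbers stand for higher toxicity in this test and higher numbers for lower toxicity in this test), compound 2 gives 26000 nM and so sits within the scatter of compound 1. Compound 3 `C/C(=C\c1ccccc1)C(=O)/C=C/c1ccc(N(C)C)cc1` carries dimethylamino in place of nitro on an aromatic carbon, para to a large group (dimethylamino in place of nitro on an aromatic carbon). For the measured compounds named here, only one measured step bears on this position: nitro in place of methoxy gave a 2.0-fold lower number from compound 1 to compound 2 (0.29 log units; within the scatter) at the same place. A single step is thin evidence, but it points to no large change in this assay. The expected step is (a 1.5-fold higher number from compound 2 to compound 3 (0.16 log units; within the scatter)) and no step beyond the scatter is anticipated. Compound 3 is estimated at 38000 nM (expected range 15000 nM to 90000 nM).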

Compound 3, half-maximal cytotoxic concentration: 20200 nM
The estimate for compound 3 lay 1.9-fold (0.27 log units) above the measured number; the range from low to high includes it.
By their numbers in this assay, from the lowest: compounds 3, 2 and 1 (each within the scatter of the next, the first and the last beyond it).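

In this assay the exchange of nitro for dimethylamino at this position gives a 1.3-fold lower number from compound 2 to compound 3 (0.11 log units; within the scatter) and so does not separate the two groups. For the compounds shown here, the exchange of methoxy for dimethylamino gives a 2.5-fold lower number from compound 1 to compound 3 (0.40 log units; beyond the scatter) and is the only step at this position beyond the scatter, though a modest one, while the two steps through nitro each stay within it. No measurement shown here accounts for these numbers. The compounds shown leave open how a primary amine, a carboxylic acid or a chlorine atom at this position would read in this assay.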